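Adding a Methoxy Group to Two Related Compounds

This account rests on a few compounds, and the source may have more. Where it says the series, first, only, none or still open, it means among the compounds named here.

Compound 1 `COc1ccc(-c2cc(/C=C/C(=O)c3ccc(N)cc3)[nH]n2)cc1` and compound 3 `COc1ccc(-c2cc(/C=C/C(=O)c3ccc(N)cc3)[nH]n2)cc1OC` share a core and differ in one place: methoxy in place of hydrogen on an aromatic carbon. In a functional assay on MDA-MB-231 cells (Homo sapiens) for cytotoxicity, read by sulforhodamine B assay, with a stated time of 48 h, tested at 10 uM (a lower number here means a stronger effect, a higher number a weaker effect of the compound at the concentration tested), compound 1 gives -7%, while compound 3 gives 24%, so the step of a number 31 percentage points higher from compound 1 to compound 3 (beyond the scatter) weakens the effect. Compound 2 `COc1ccc(C(=O)/C=C/c2cc(-c3cc(OC)c(OC)c(OC)c3)n[nH]2)cc1OC` has a different core; how it differs from the core of compound 1 is not broken down here. In this assay compound 2 gives -82%, the strongest effect of the three. Compound 4 `COc1cc(C(=O)/C=C/c2cc(-c3cc(OC)c(OC)c(OC)c3)n[nH]2)cc(OC)c1OC` is not yet measured and differs from compound 2 by the same kind of change: methoxy in place of hydrogen on an aromatic carbon. The surroundings are not identical, since in compound 4 the new methoxy group also sits meta to a methoxy group. Because the earlier step of a number 31 percentage points higher from compound 1 to compound 3 (beyond the scatter) weakened the effect, a weakening step is expected for compound 4 too, estimated as a number 27 percentage points higher from compound 2 to compound 4 (beyond the scatter). Compound 4 is therefore expected to give about -55% in this assay, between -90% and -15%.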

Compound 4, a percentage reported as activity, at one concentration (the size of the read-out at that concentration, not a potency): -53%
The estimate for compound 4 lay 2 percentage points below the measured number, and the stated range covers the measured number.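

In this assay, methoxy in place of hydrogen on an aromatic carbon gives a number 29 percentage points higher from compound 2 to compound 4 (beyond the scatter) and so weakens the effect on the core of compound 2 as it did on the core of compound 1. The two steps match in size, so in this series the change carried over from one core to the other: the same change on two cores in this assay, a number 31 percentage points higher (beyond the scatter) from compound 1 to compound 3 and a number 29 percentage points higher (beyond the scatter) from compound 2 to compound 4, 2 percentage points apart, within the scatter of two such steps.
For the compounds shown here, this rests on only two pairs of compounds, and it does not show that the change would act alike on any other core or at any other place on the ring.

The compounds shown leave open whether another group in the same place, such as a hydroxyl group, a fluorine atom or a longer ethoxy chain, would shift the read-out by a similar amount.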